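A Smaller Group on the Aromatic Carbon: Compound 4

The source may hold more compounds than are shown below. What is called first, only, known or untested is meant among the compounds shown, and "the series" means these compounds.

Compound 1 `CC(=O)c1ccc2c(c1)C(n1ccccc1=O)=CC(C)(C)O2` gives 6.65 in a functional assay (trachea) with Rattus norvegicus as the target; a higher number here means a more potent compound, by a factor of ten per unit of this negative logarithm, a lower number a less potent compound.
Compound 2 `CC1(C)C=C(n2ccccc2=O)c2cc(C(=O)c3ccccc3F)ccc2O1` gives 6.34 in this assay.
Compound 3 `CC1(C)C=C(n2ccccc2=O)c2cc(C(=N)NO)ccc2O1` gives 5.51 in this assay.

Compound 3 is the least potent of the three, as both a number 1.14 log units lower from compound 1 to compound 3 (beyond the scatter) and a number 0.83 log units lower from compound 2 to compound 3 (beyond the scatter) lie beyond the scatter. Compound 4 `CC1(C)C=C(n2ccccc2=O)c2cc(C#N)ccc2O1` changes compound 3 as follows: a group of 2 heavy atoms (1 carbon, 1 nitrogen; no ring) in place of a group of 4 heavy atoms (1 carbon, 2 nitrogen, 1 oxygen; no ring), on an aromatic carbon. Within the data shown here, no measured step exchanges the group of 4 heavy atoms for cyano, so the measured steps bear on it only indirectly: they show that this group sits well below the two others at the same aromatic carbon. Compound 4 is therefore expected to lie between those extremes, with a modest gain estimated as a number 0.49 log units higher from compound 3 to compound 4 (beyond the scatter). The estimate for compound 4 in this assay is 6, with a range from 5.3 to 6.7.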

Compound 4, logarithm of the reciprocal of the active concentration, log(1/C): 7.1
Estimate against measurement, compound 4: 1.10 log units below; the measured number lies above the stated range.
By their numbers in this assay, from the lowest: compound 3; then compound 2; then compound 1; then compound 4.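

In this assay the cyano group gives the highest number of the series, above all three earlier groups at this aromatic carbon (a number 1.59 log units higher from compound 3 to compound 4 (beyond the scatter); a number 0.76 log units higher from compound 2 to compound 4 (beyond the scatter); a number 0.45 log units higher from compound 1 to compound 4 (beyond the scatter)). Among these compounds, the position therefore needs no carbonyl group, although the only earlier compound without one, compound 3, stood lowest. Group size alone does not set the order either, as compound 2 goes against it, and no measurement here accounts for the gain.

Going by these compounds, it remains open whether trifluoromethyl, a carboxylic acid or an amine on this carbon would match the cyano group.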